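This account rests on a few compounds, and the source may have more. Where it says the series, first, only, none or still open, it means among the compounds named here.

Of the compounds shown here, two sharing one core have been measured so far, compound 1 (`CN(C)CCCNc1nc2cc([N+](=O)[O-])ccc2nc1NCc1cccc(C(F)(F)F)c1`) and compound 2 (`CN(C)CCCNc1nc2cc([N+](=O)[O-])ccc2nc1NCc1cc(F)cc(C(F)(F)F)c1`). In an ADME assay on HEK293 cells (Homo sapiens) for cytotoxicity, read by MTT assay, with a stated time of 24 h (a higher number here means a weaker inhibitor, a lower number a stronger inhibitor), compound 1 gives 7.99 ug/mL, while compound 2 gives 2.67 ug/mL, the lower of the two numbers. Going by the values given here, the only measured step is a 3.0-fold lower number from compound 1 to compound 2 (0.48 log units; beyond the scatter), and it places fluoro in place of hydrogen on an aromatic carbon.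

Compound 3 (`CN(C)CCCNc1nc2cc([N+](=O)[O-])ccc2nc1NCc1cc(C(F)(F)F)cc(C(F)(F)F)c1`) has yet to be measured. It differs from compound 2 by trifluoromethyl in place of fluoro on an aromatic carbon. In words, this is trifluoromethyl in place of fluoro on an aromatic carbon, meta to a trifluoromethyl group.

Among the compounds with values here, no measured step covers this exchange directly. Within the data shown here, the one step that bears on it starts from hydrogen on that carbon, whereas compound 2 and compound 3 both carry a substituent there. That modest step therefore offers only weak guidance, and no clear move in either direction is expected in this assay. The expected result is a 1.1-fold lower number from compound 2 to compound 3 (0.03 log units; within the scatter), a change estimated to stay within the scatter. For compound 3 the estimated value is 2.5 ug/mL, with an expected range of 1 ug/mL to 6.5 ug/mL.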

Compound 3, half-maximal inhibitory concentration: 4.32 ug/mL
Compound 3: the middle estimate sits 1.7-fold (0.24 log units) below what was measured; the measured number falls inside the stated range.
By their numbers in this assay, from the lowest: compounds 2, 3 and 1 (each within the scatter of the next, the first and the last beyond it).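

In this assay the position that holds hydrogen in compound 1 and fluoro in compound 2 now carries trifluoromethyl, and taking fluoro out for this group gives a 1.6-fold higher number from compound 2 to compound 3 (0.21 log units; within the scatter) while the same group in place of hydrogen gives a 1.8-fold lower number from compound 1 to compound 3 (0.27 log units; within the scatter) on the same scale. Going by these compounds alone, compound 3 thus cannot be told apart from either compound 1 or compound 2, even though those two remain separated by a 3.0-fold lower number from compound 1 to compound 2 (0.48 log units; beyond the scatter) and so the hydrogen-to-fluoro exchange is the only step at this position that lies beyond the scatter, with the larger trifluoromethyl group not extending it. Nothing offered alongside these numbers accounts for this outcome.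

Going by these compounds, whether a group of another kind at this position, such as methoxy, an amine or a carboxylic acid, would give a step beyond the scatter remains open. Also open, on these data alone, is whether the fluoro step would hold with the existing trifluoromethyl group replaced by a different group, since all three compounds keep that group and the rest of the shared core unchanged.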